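The source may report more compounds than this note shows. Statements on the series, on what has been measured and on what is new or still open speak of the compounds shown alone.

Of the compounds shown here, three have been measured in an assay on liver for inhibition of estradiol 17-beta-dehydrogenase 2 (Mus musculus), read by HPLC, in the presence of a further agent that is not named here; a higher number here means a weaker inhibitor, a lower number a stronger inhibitor. Compound 1 `Cc1ccc(S(=O)(=O)Nc2cccc(-c3ccc(C(=O)c4cc(F)c(F)c(O)c4F)s3)c2)cc1` gives 9.9 nM in this assay. Compound 2 `O=C(c1ccc(-c2cccc(NS(=O)(=O)c3cccc(Cl)c3)c2)s1)c1cc(F)c(F)c(O)c1F` gives 5.6 nM in this assay. Going by the values given here, the only one-place step between measured compounds, a 1.8-fold lower number from compound 1 to compound 2 (0.25 log units; within the scatter), concerns the aryl group on the sulfonyl sulfur alone. Compound 3 `O=C(c1ccc(-c2cccc(NS(=O)(=O)c3ccccc3)c2)s1)c1c(F)ccc(O)c1Cl` gives 2.7 nM in this assay, the lowest of the three numbers; its gap to compound 2 and its gap to compound 1 both lie beyond the scatter. Compound 3 differs from the other two in more than one place, so for those pairs only the two numbers themselves can be stated.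

Compound 4 `O=C(c1ccc(-c2cccc(NS(=O)(=O)c3ccccc3)c2)s1)c1cccc(O)c1Cl` has not yet been measured. It differs from compound 3 by hydrogen in place of fluoro on an aromatic carbon. Among the compounds with values here, no measured step bears on this change: the one step in hand, a 1.8-fold lower number from compound 1 to compound 2 (0.25 log units; within the scatter), touches the sulfonyl aryl group and says nothing about the aryl ketone part. Within the data shown here, with a single fluorine removed and no comparable precedent, the step in this assay is expected to be small, most likely within the scatter, with a slight lean toward a higher number. Compound 4 is therefore estimated in this assay at 5 nM, with a range of 1.5 nM to 17 nM. The expected step of a 1.9-fold higher number from compound 3 to compound 4 (0.27 log units; within the scatter) is accordingly modest.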

Compound 4, half-maximal inhibitory concentration: 2.7 nM
Beside the measured number, compound 4's estimate is 1.9-fold (0.27 log units) above it; the measured number falls inside the stated range.
By their numbers in this assay, from the lowest: compounds 3 and 4 (each within the scatter of the next); then compounds 2 and 1 (each within the scatter of the next).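

In this assay, going by these compounds alone, hydrogen in place of fluoro on the aromatic carbon para to the hydroxy group gives no change at the digits printed from compound 3 to compound 4 (within the scatter), the first one-place reading on the aryl ketone part, since the earlier step touched only the aryl group on the sulfonyl sulfur. For this pair, the 2-chloro-6-fluoro-3-hydroxyphenyl and 2-chloro-3-hydroxyphenyl groups cannot be told apart in this assay, so the fluoro at this carbon, ortho to a large group and meta to the chloro group, is not required to keep the number of compound 4 at the level of compound 3. No measurement in hand accounts for this result.

Open is whether this carbon would give the same reading with a different group on it, such as a methoxy group, a trifluoromethyl group or an amine, since only fluoro and hydrogen are shown here. Also open, going by these compounds, is whether the same exchange would read alike with 3-chlorophenyl or 4-methylphenyl on the sulfonyl sulfur, or with the other halogen pattern of compound 1 and compound 2 on the aryl ketone part.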